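A few compounds are considered here, and "the series" means these few. Any claim that something is new, unique, unknown or untested is made for them only; others in the source may bear on it.

Of the compounds shown here, three share one core and have been tested in a functional assay on cells (Cancer cell lines, Homo sapiens) for cytotoxicity, read by sulforhodamine B assay, with a stated time of 48 h; on this read-out higher numbers stand for weaker inhibition of growth and lower numbers for stronger inhibition of growth. Compound 1 `O=C1N=C(N2N=C(c3ccccc3)CC2c2ccccc2O)S/C1=C1/C(=O)Nc2ccc(Br)cc21` gives 940 nM in this assay. Going by the values given here, compound 2 `COc1ccc(C2CC(c3ccccc3)=NN2C2=NC(=O)/C(=C3\C(=O)Nc4ccc(Br)cc43)S2)cc1` gives 3630 nM in this assay; the single measured step, a 3.9-fold higher number from compound 1 to compound 2 (0.59 log units; beyond the scatter), concerns a substituent on a saturated ring carbon and not the aromatic ring treated below. Compound 3 `CN(C)c1ccc(C2CC(c3ccccc3)=NN2C2=NC(=O)/C(=C3\C(=O)Nc4ccccc43)S2)cc1` gives 39700 nM in this assay, the highest number of the three; it sits well beyond the scatter from compound 2 and still further from compound 1. Compound 4 `CN(C)c1ccc(C2CC(c3ccccc3)=NN2C2=NC(=O)/C(=C3\C(=O)Nc4ccc(Br)cc43)S2)cc1` differs from compound 3 by bromo in place of hydrogen on an aromatic carbon. Among the compounds with values here, no measured step isolates this change: compound 2 and compound 3 differ in two places at once, so their two values only show that the compound carrying bromine gave the lower number. Both bromine-bearing compounds, compound 1 and compound 2, gave lower numbers than compound 3, so a downward step is expected, a 4.0-fold lower number from compound 3 to compound 4 (0.60 log units; beyond the scatter), with wide uncertainty. Compound 4 is therefore estimated at 10000 nM in this assay, expected to lie between 2500 nM and 40000 nM.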

Compound 4, concentration for total growth inhibition: 690 nM
Compound 4: middle estimate off by 14-fold (1.16 log units), on the high side; the whole stated range lies above it.
By their numbers in this assay, from the lowest: compounds 4 and 1 (each within the scatter of the next); then compound 2; then compound 3.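

In this assay, going by these compounds alone, bromo in place of hydrogen on an aromatic carbon of the fused two-ring system gives a 58-fold lower number from compound 3 to compound 4 (1.76 log units; beyond the scatter), so this single atom alone produces a large step, which no earlier pair could isolate. With bromo present, dimethylamino in place of methoxy on an aromatic carbon gives a 5.3-fold lower number from compound 2 to compound 4 (0.72 log units; beyond the scatter), showing that this group also matters, while 4-(dimethylamino)phenyl in place of 2-hydroxyphenyl on a saturated ring carbon gives a 1.4-fold lower number from compound 1 to compound 4 (0.13 log units; within the scatter), which leaves those two compounds indistinguishable. The data offer no explanation for the size of the bromo step.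

On these data alone, it remains open whether chloro, fluoro or methyl at the same aromatic carbon would act as bromo does. It is also unclear whether hydrogen in place of bromo would cost as much in the methoxy and 2-hydroxyphenyl compounds.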